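Sulfonamide Aryl Swap in an Antiproliferative Series

This account rests on a few compounds, and the source may have more. Where it says the series, first, only, none or still open, it means among the compounds named here.

Of the compounds shown here, two of a shared core have been tested in a functional assay on DU-145 cells (Homo sapiens) for antiproliferative activity, read by MTT assay, with a stated time of 72 h; on this read-out lower numbers stand for stronger inhibition and higher numbers for weaker inhibition. Compound 1 `COc1cccc(N(C)S(=O)(=O)C2CC3OC2C(c2ccc(NC(=O)CCCCCCC(=O)O)cc2)=C3c2ccc(O)cc2)c1` gives 62200 nM in this assay. Compound 2 `CN(c1cccc2ccccc12)S(=O)(=O)C1CC2OC1C(c1ccc(NC(=O)CCCCCCC(=O)O)cc1)=C2c1ccc(O)cc1` gives 70900 nM in this assay. Among these two numbers compound 2 holds the higher one, and the change a 1.1-fold higher number from compound 1 to compound 2 (0.06 log units; within the scatter) amounts to the replacement of 3-methoxyphenyl by naphthalen-1-yl on a sulfonamide nitrogen, so the two values do not differ in any meaningful way.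

Compound 3 `CCN(c1ccc(O)cc1)S(=O)(=O)C1CC2OC1C(c1ccc(NC(=O)CCCCCCC(=O)O)cc1)=C2c1ccc(O)cc1` is not yet measured. It differs from compound 2 as follows: ethyl(4-hydroxyphenyl)amino in place of methyl(naphthalen-1-yl)amino on a sulfonyl sulfur. For the measured compounds named here, the only step on record that touches the same part of the molecule, the substituent on the sulfonyl sulfur, is the one from compound 1 to compound 2, and that step stayed within the scatter. Going by the values given here, no measured pair speaks to a hydroxyl replacing an aromatic ring at this position, so the expectation rests on that single step alone. The account therefore expects no step beyond the scatter, a 1.2-fold lower number from compound 2 to compound 3 (0.07 log units; within the scatter), for compound 3 in this assay. Compound 3 is estimated at 60000 nM, in a range from 25000 nM to 150000 nM.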

Compound 3, half-maximal inhibitory concentration: > 100000 nM
Compound 3 ended at the assay's limit; the forecaster's own chance of this, stated with the estimate: 10%; middle value at least 1.6-fold (0.22 log units) from the limit.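

In this assay compound 3 stands at a limit of the read-out and not at a number: the limit of > 100000 nM in this assay, at which 1 of the 3 values shown sits. Read against that limit, the change on the sulfonyl sulfur gives an at least 1.4-fold higher number from compound 2 to compound 3 (0.14 log units; that floor lies within the scatter) and an at least 1.6-fold higher number from compound 1 to compound 3 (0.20 log units; that floor lies within the scatter), so each step is known only as a floor, and both floors stay within the scatter. For the compounds shown here, the earlier pair, with numbers at both ends, showed only that one aryl group on the sulfonamide nitrogen could take the place of another with no meaningful difference; ethyl(4-hydroxyphenyl)amino, with its hydrogen-bond donor and acceptor, now gives a result with no upper end, so this position may tolerate the change or may lose more than the scatter, and the floors cannot decide which.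

Compound 3 alters both the alkyl group and the aryl group on the nitrogen at once, and the compounds shown leave open which of the two carries the result. Also open, going by these compounds, is how this position would read with a methyl group kept on the nitrogen and a 4-hydroxyphenyl ring beside it, or with a cyclohexyl group or a carboxylic acid on the aryl ring.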